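From isopropyl to tert-butyl on a shared core

The source may hold more compounds than are shown below. What is called first, only, known or untested is meant among the compounds shown, and "the series" means these compounds.

In a functional assay on the whole organism for inhibition, with Scenedesmus acutus as the target (a lower number here means a stronger inhibitor, a higher number a weaker inhibitor), compound 1 `O=C(O)c1cc(N2C(=O)C3=C(CCCC3)C2=O)ccc1Cl` gives > 100000 nM, which is a limit of the assay and not a number. Compound 2 `CCOC(=O)c1cc(N2C(=O)C3=C(CCCC3)C2=O)ccc1Cl` carries ethyl in place of the hydrogen on that oxygen and gives 1910 nM. Compound 3 `CC(C)OC(=O)c1cc(N2C(=O)C3=C(CCCC3)C2=O)ccc1Cl` carries isopropyl there and gives 1230 nM. Both replacements are large steps: an at least 52-fold lower number from compound 1 to compound 2 (1.71 log units; beyond the scatter), and an at least 81-fold lower number from compound 1 to compound 3 (1.91 log units; beyond the scatter). Between the two alkyl groups, the numbers stay level: a 1.6-fold lower number from compound 2 to compound 3 (0.19 log units; within the scatter). Compound 3 therefore stands alongside compound 2, far from the limit.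

Compound 4 `CC(C)(C)OC(=O)c1cc(N2C(=O)C3=C(CCCC3)C2=O)ccc1Cl` has methyl in place of hydrogen on a saturated chain carbon bound to an oxygen next to a carbonyl group and two saturated chain carbons, which turns isopropyl to tert-butyl: methyl in place of hydrogen on a saturated chain carbon bound to an oxygen next to a carbonyl group and two saturated chain carbons. The large steps replaced the hydrogen on the oxygen itself, and compound 4 keeps that replacement, so they say little here. The closer guide is the similar addition of methyl from compound 2 to compound 3, a 1.6-fold lower number from compound 2 to compound 3 (0.19 log units; within the scatter). One such step is thin evidence, but it points to no change beyond the scatter in this assay. The expected result is a 1.2-fold higher number from compound 3 to compound 4 (0.09 log units; within the scatter). Compound 4 is estimated at 1500 nM, with an expected range of 500 nM to 5000 nM.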

Compound 4, half-maximal inhibitory concentration: 81300 nM
Compound 4: the middle estimate sits 54-fold (1.73 log units) below what was measured; measured number above the stated range.
By their numbers in this assay, from the lowest: compounds 3 and 2 (each within the scatter of the next); then compound 4. At a limit, above all of these: compound 1.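

In this assay, the saturated chain carbon bound to an oxygen next to a carbonyl group turns out not to accept added methyl groups evenly: the change from isopropyl to tert-butyl gives a 66-fold higher number from compound 3 to compound 4 (1.82 log units; beyond the scatter), although the earlier addition of one methyl, from ethyl to isopropyl, stayed within the scatter. Measured against the ethyl compound, tert-butyl likewise costs a great deal, with a 43-fold higher number from compound 2 to compound 4 (1.63 log units; beyond the scatter), so the response at this position is a sudden drop rather than a gradual trend, and simply having an alkyl group on that oxygen is not enough to give the low numbers of compound 2 and compound 3. Against the parent acid, the result is an at least 1.2-fold lower number from compound 1 to compound 4 (0.08 log units; that floor lies within the scatter), a floor that does not separate the two compounds, and how far apart they really lie stays unknown because the value of compound 1 is a limit of the assay: the limit of > 100000 nM in this assay, at which 1 of the 4 values shown sits.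

The compounds shown leave open whether the drop follows from the third methyl on that carbon or from the overall size of the group. A longer straight chain such as n-butyl, or an amide in place of the ester, could help tell these readings apart.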